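Oxalamide series: chloro for fluoro on the methylpiperazine core

This account rests on a few compounds, and the source may have more. Where it says the series, first, only, none or still open, it means among the compounds named here.

In an ADME assay on the whole organism (Rattus norvegicus, strain Sprague-Dawley) for pharmacokinetics, using cassette dosing, at a dose of 1 mg/kg by the oral route (a lower number here means that a smaller share of the oral dose reaches the circulation, a higher number that a larger share of the oral dose reaches the circulation), compound 1 `O=C(Nc1ccc2[nH]c(=O)oc2c1)C(=O)N1CCN(c2ccc(F)c(F)c2)CC1` gives 13%. Compound 2 `O=C(Nc1ccc2[nH]c(=O)oc2c1)C(=O)N1CCN(c2ccc(F)c(Cl)c2)CC1` gives 24.6% in this assay, and compound 3 `C[C@@H]1CN(c2ccc(F)c(F)c2)CCN1C(=O)C(=O)Nc1ccc2[nH]c(=O)oc2c1` gives 118%. Compound 2 differs from compound 1 by chloro in place of fluoro on an aromatic carbon, and compound 3 from compound 1 by methyl in place of hydrogen on a saturated ring carbon, with a number 105 percentage points higher from compound 1 to compound 3 (beyond the scatter). Compound 4 `C[C@@H]1CN(c2ccc(Cl)c(F)c2)CCN1C(=O)C(=O)Nc1ccc2[nH]c(=O)oc2c1` differs from compound 3 by chloro in place of fluoro on an aromatic carbon. This is the same kind of change as from compound 1 to compound 2, not the same: there the place is meta to a large group, here it is para to a large group. For the measured compounds named here, a step of roughly the earlier size is expected, no change at the digits printed from compound 3 to compound 4 (within the scatter), because the one measured step of this kind is a number 11.6 percentage points higher from compound 1 to compound 2 (beyond the scatter), on a different core. Compound 4 is expected at 118%, between 75% and 160%.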

Compound 4, oral bioavailability: 30.4%
Compound 4: the middle estimate sits 87.6 percentage points above what was measured; measured number below the stated range.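

In this assay chloro in place of fluoro on an aromatic carbon gives a number 87.6 percentage points lower from compound 3 to compound 4 (beyond the scatter) and so the change does not carry over between these two cores in size or direction: the same change on two cores in this assay, a number 11.6 percentage points higher (beyond the scatter) from compound 1 to compound 2 and a number 87.6 percentage points lower (beyond the scatter) from compound 3 to compound 4, 99.2 percentage points apart, beyond the scatter of two such steps

The two steps also differ in place, meta to a large group on the core of compound 1 and para to a large group on the core of compound 3, and the pair does not tell whether the core or the place accounts for the gap. One step on each core gives no general rule for this change.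

Open, as far as these compounds go, is how chloro meta to a large group behaves on the core of compound 3. Also open, from the compounds shown here alone, is how a nitrile or a methoxy group in place of that fluoro compares in this assay on the same core.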